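The source may hold more compounds than are shown below. What is called first, only, known or untested is meant among the compounds shown, and "the series" means these compounds.

Compound 1, `CNC(=O)/C=C/c1ccc2noc(-c3ccccc3)c2c1`: in an assay for inhibition of inositol hexakisphosphate kinase 3 (Homo sapiens), read by colorimetric assay, coupled enzyme assay and malachite green, with a stated time of 120 min, in the presence of a further agent that is not named here (a higher number here means a weaker inhibitor, a lower number a stronger inhibitor), compound 1 gives 42600 nM.
Compound 2, `Cc1cccc(-c2onc3ccc(/C=C/C(=O)O)cc23)c1`: in this assay compound 2 gives 3590 nM.
Compound 3, `O=C(O)c1ccc2noc(-c3ccc(-c4cccnc4)cc3)c2c1`: in this assay compound 3 gives 610 nM.

Of these three, compound 3 has the lowest number and is therefore the strongest inhibitor of the set. Its nearest neighbour is compound 2, whose number is higher by a gap that lies beyond the usual scatter, and compound 1 lies further still, also beyond the scatter. Going by the values given here, no pair among the three differs in only one place, so no single structural step can be read from the measured compounds.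

Compound 4, `O=C(O)c1ccc2noc(-c3ccc(NC(=O)C4CCCC4)cc3)c2c1`, keeps the core and the acid of compound 3 and differs in one place: (cyclopentylcarbonyl)amino in place of pyridin-3-yl on an aromatic carbon. Among the compounds with values here, a (cyclopentylcarbonyl)amino group brings a hydrogen-bond donor that the pyridin-3-yl group lacks and a non-aromatic ring in place of an aromatic one, but nothing among the measured compounds shows how such a swap affects the number in this assay. The expectation is a moderate weakening, with a step beyond the scatter in the direction of a higher number: the step from compound 3 to compound 4 is estimated at a 2.5-fold higher number from compound 3 to compound 4 (0.39 log units; beyond the scatter). For compound 4 a value of 1500 nM is expected in this assay, within a range of 400 nM to 6000 nM.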

Compound 4, half-maximal inhibitory concentration: 240 nM
For compound 4 the middle estimate is 6.3-fold (0.80 log units) above the measured one; the whole stated range lies above it.
By their numbers in this assay, from the lowest: compound 4; then compound 3; then compound 2; then compound 1.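

Going by these compounds alone, this is the first comparison in the set between two compounds that differ in only one place: in this assay, (cyclopentylcarbonyl)amino in place of pyridin-3-yl, on an aromatic carbon para to a large group, gives a 2.5-fold lower number from compound 3 to compound 4 (0.41 log units; beyond the scatter), a modest step but one beyond the usual scatter. For this pair, then, an aromatic ring at this position is not needed for a low number, since a five-membered non-aromatic ring of carbon only, in a group that also brings a hydrogen-bond donor, gives the lower number of the two. Nothing given here bears on why the number falls.

This single swap changes the ring, the amide hydrogen and the carbonyl together, so the compounds shown do not tell which of these parts accounts for the step; an acetylamino group, or a cyclohexyl or phenyl ring on the same amide, would begin to separate them. Also open, as far as these compounds go, is whether the step holds with the carboxylic acid of compound 4 replaced by a methyl amide or a primary amide.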